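The source may report more compounds than this note shows. Statements on the series, on what has been measured and on what is new or still open speak of the compounds shown alone.

Values measured in a functional assay on SMMC-7721 cells (Homo sapiens) for cytotoxicity, read by MTT assay, with a stated time of 72 h; a higher number here means a weaker inhibitor, a lower number a stronger inhibitor:

Compound 1 `COc1cc(C=C2C(=O)N(c3ccc(Cl)cc3)N(c3ccc(Cl)cc3)C2=O)ccc1O`: 64900 nM
Compound 2 `COc1cccc(C=C2C(=O)N(c3ccc(Cl)cc3)N(c3ccc(Cl)cc3)C2=O)c1O`: 64900 nM
Compound 3 `O=C1C(=Cc2cccc(Cl)c2)C(=O)N(c2ccc(Cl)cc2)N1c1ccc(Cl)cc1`: 20200 nM

Compound 3 has the lowest number of the three in this assay, which makes it the strongest inhibitor of this small set, though only by a modest margin. Compound 4 `COc1cccc(C=C2C(=O)N(c3ccc(Cl)cc3)N(c3ccc(Cl)cc3)C2=O)c1OC`, still to be measured, keeps the shared core and differs from compound 3 in one group: 2,3-dimethoxyphenyl in place of 3-chlorophenyl on a double-bonded chain carbon bound to a double-bonded ring carbon.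

The measured steps that bear on this change the same place. One shows a 3.2-fold lower number from compound 1 to compound 3 (0.51 log units; beyond the scatter), and the other shows a 3.2-fold lower number from compound 2 to compound 3 (0.51 log units; beyond the scatter). Read in reverse, both suggest that leaving 3-chlorophenyl for a methoxy-bearing phenyl group raises the number. A third step, no change at the digits printed from compound 1 to compound 2 (within the scatter), shows no separation between the 4-hydroxy-3-methoxyphenyl and 2-hydroxy-3-methoxyphenyl groups. For the measured compounds named here, no measured compound carries the 2,3-dimethoxyphenyl group, so the size of the change remains uncertain. A rise of similar size is expected, and the estimated step is a 2.7-fold higher number from compound 3 to compound 4 (0.44 log units; beyond the scatter). For compound 4 the estimated value is 55000 nM, with an expected range of 22000 nM to 130000 nM.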

Compound 4, half-maximal inhibitory concentration: 14100 nM
Compound 4: the middle estimate sits 3.9-fold (0.59 log units) above what was measured, and the stated range ends above it.
By their numbers in this assay, from the lowest: compounds 4 and 3 (each within the scatter of the next); then compounds 1 and 2 (each within the scatter of the next).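

In this assay, the change at this place on a double-bonded chain carbon bound to a double-bonded ring carbon gives a 1.4-fold lower number from compound 3 to compound 4 (0.16 log units; within the scatter), so 2,3-dimethoxyphenyl and 3-chlorophenyl cannot be told apart here, and a methoxy-bearing phenyl group does not by itself go with a higher number. The sharper contrast lies at the oxygen on the aromatic ring: methyl in place of hydrogen gives a 4.6-fold lower number from compound 2 to compound 4 (0.66 log units; beyond the scatter), and the 2,3-dimethoxyphenyl group in place of 4-hydroxy-3-methoxyphenyl gives a 4.6-fold lower number from compound 1 to compound 4 (0.66 log units; beyond the scatter), so among these four compounds the two carrying a hydroxy group have the higher numbers, with no compound going against this. No independent measurement bears on why the hydroxy-bearing compounds separate from the other two.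

The compounds shown leave open whether the pattern extends to an ethoxy group or a longer chain on that oxygen, or to a phenyl group carrying an amine or a carboxylic acid. They also leave open whether a hydroxy group alone, with no methoxy group on the same phenyl ring, would match compound 1 and compound 2.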